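The source may report more compounds than this note shows. Statements on the series, on what has been measured and on what is new or still open speak of the compounds shown alone.

Working notes on the series, all values read in a functional assay on HepG2 cells (Homo sapiens) for cytotoxicity, read by MTT assay, with a stated time of 72 h; a lower number here means a stronger inhibitor, a higher number a weaker inhibitor. Compound 1 (`CNC(=O)c1cc(Oc2ccc(C(=O)/C=C/c3ccc(OC)c(OC)c3OC)cc2)ccn1`) gives 9810 nM, compound 2 (`CNC(=O)c1cc(Oc2ccc(C(=O)/C=C/c3ccc(F)cc3Cl)cc2)ccn1`) gives 7320 nM, and compound 3 (`CNC(=O)c1cc(Oc2ccc(C(=O)/C=C/c3cc(OC)c(OC)c(OC)c3)cc2)ccn1`) gives 560 nM. Compound 2 therefore stands in the upper part of this small set: its number lies within the scatter of compound 1 and beyond the scatter of compound 3, which has the lower number.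

Compound 4 (`CNC(=O)c1cc(Oc2ccc(C(=O)/C=C/c3ccc(Cl)cc3Cl)cc2)ccn1`) has not yet been measured. It differs from compound 2 by chloro in place of fluoro on an aromatic carbon, meta to a chloro group and para to a large group. The same difference reads 2-chloro-4-fluorophenyl to 2,4-dichlorophenyl.

Among the compounds with values here, no measured pair isolates this exchange, so there is no direct precedent for its size. Within the data shown here, the only anchor is compound 2 at 7320 nM. A slight shift towards a lower number is expected, but nothing beyond the scatter. The estimated change is a 1.2-fold lower number from compound 2 to compound 4 (0.09 log units; within the scatter), which is expected to stay within the scatter. For compound 4 the estimate is 6000 nM, with an expected range of 2800 nM to 13000 nM.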

Compound 4, half-maximal inhibitory concentration: 11700 nM
Beside the measured number, compound 4's estimate is 2.0-fold (0.29 log units) below it, within the range that was stated.
By their numbers in this assay, from the lowest: compound 3; then compounds 2, 1 and 4 (each within the scatter of the next).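

In this assay, chloro in place of fluoro on an aromatic carbon, meta to a chloro group and para to a large group, gives a 1.6-fold higher number from compound 2 to compound 4 (0.20 log units; within the scatter). Within the data shown here, this is the only pair that differs in one place, and it gives the first direct reading at this position: with the rest of the molecule held constant, 2-chloro-4-fluorophenyl and 2,4-dichlorophenyl cannot be told apart in this assay, so this exchange of one halogen for another leaves the number unresolved from the scatter. No measurement at hand bears on the reason for this result, so the reading stays a bare comparison of two values.

The compounds shown leave open whether this position responds to anything other than a halogen, since an amine, a carboxylic acid or a trifluoromethyl group in place of the chloro of compound 4 would test a far wider change than this one. Among these compounds, they also leave open whether the same exchange would read alike without the chloro group on the same ring, as no pair here separates the two halogens from each other in that setting.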